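The source may hold more compounds than are shown below. What is called first, only, known or untested is meant among the compounds shown, and "the series" means these compounds.

Compound 1 `Cc1ccc(-n2cc(COc3cccc4cnc(Nc5cccc(Cl)c5)nc34)nn2)c([N+](=O)[O-])c1`: 25000 nM
Compound 2 `Clc1ccc(-n2cc(COc3cccc4cnc(Nc5cccc(Cl)c5)nc34)nn2)cc1`: 24000 nM

Both values come from a functional assay on Huh-7 cells (Homo sapiens) for cytotoxicity, read by cell counting, with a stated time of 48 h; a higher number here means a weaker inhibitor, a lower number a stronger inhibitor. Compound 2 stands level with compound 1, and the two numbers cannot be ranked. Compound 3 `COc1ccccc1-n1cc(COc2cccc3cnc(Nc4cccc(Cl)c4)nc23)nn1` keeps the shared core of compound 2 and carries 2-methoxyphenyl in place of 4-chlorophenyl on an aromatic nitrogen of a five-membered aromatic ring with 3 nitrogen (2-methoxyphenyl in place of 4-chlorophenyl on an aromatic nitrogen).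

Among the compounds with values here, only one measured step bears on this change, as it exchanged one substituted phenyl group for another on that same nitrogen: a 1.0-fold lower number from compound 1 to compound 2 (0.02 log units; within the scatter). Within the data shown here, that is a single step, and no measured compound carries 2-methoxyphenyl, so the guidance is thin. Among the measured compounds shown here, with a 1.0-fold lower number from compound 1 to compound 2 (0.02 log units; within the scatter) as the only guide, no step beyond the scatter is expected in this assay, and no direction can be favoured. The expected change is an estimated no change at the digits printed from compound 2 to compound 3 (within the scatter). The estimate for compound 3 is 24000 nM, with an expected range from 11000 nM to 50000 nM.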

Compound 3, half-maximal inhibitory concentration: 7000 nM
Beside the measured number, compound 3's estimate is 3.4-fold (0.54 log units) above it; the whole stated range lies above it.
By their numbers in this assay, from the lowest: compound 3; then compounds 2 and 1 (each within the scatter of the next).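

In this assay, the group on the aromatic nitrogen of the five-membered ring turns out to matter: 2-methoxyphenyl gives a 3.4-fold lower number from compound 2 to compound 3 (0.54 log units; beyond the scatter), and against 4-methyl-2-nitrophenyl it gives a 3.6-fold lower number from compound 1 to compound 3 (0.55 log units; beyond the scatter). The earlier pair had shown no step beyond the scatter at this nitrogen, so compound 3 is the first sign that exchanging one substituted phenyl group for another here can move the number, with both modest steps pointing towards a stronger inhibitor. Nothing available accounts for this shift, so the result stands as an observation only.

The three compounds leave open whether the lower number belongs to the methoxy group as such or to its place on the phenyl ring, a question that 4-methoxyphenyl would address directly. They also do not tell whether an amine on that phenyl ring, a longer ethoxy chain in place of the methoxy, or a carboxylic acid would lower the number further, leave it level or raise it again.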